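From thiophen-2-yl to 4-methylphenyl at the assay limit

The source may hold more compounds than are shown below. What is called first, only, known or untested is meant among the compounds shown, and "the series" means these compounds.

In a functional assay on AGS cells (Homo sapiens) for inhibition, read by reporter gene assay (on this read-out lower numbers stand for stronger inhibition and higher numbers for weaker inhibition), compound 1 `O=C(COc1ccc(F)cc1)Nc1cccc(C(=O)O)c1` gives > 30000 nM as a limit, not a number. Compound 2 `O=C(COc1ccc(-c2cccs2)cc1)Nc1cccc(C(=O)O)c1` gives > 30000 nM as a limit as well, so its standing is known only to that extent. Within the data shown here, the series so far reads as the limit of > 30000 nM in this assay, at which 2 of the 2 values shown sit, and nothing finer.

Compound 3 `Cc1ccc(-c2ccc(OCC(=O)Nc3cccc(C(=O)O)c3)cc2)cc1` carries 4-methylphenyl in place of thiophen-2-yl on an aromatic carbon, para to a large group (4-methylphenyl in place of thiophen-2-yl on an aromatic carbon). Among the measured compounds shown here, only one measured step bears on this place (a step that the two limits leave unreadable from compound 1 to compound 2), and it offers neither a size nor a direction to carry forward. The expected change in this assay is therefore none beyond the scatter (a number no higher from compound 2 to compound 3 (the limit leaves the size open)). The estimate for compound 3 is 30000 nM with an expected range from 10000 nM to 60000 nM and a good chance that the assay again reports only a limit.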

Compound 3, half-maximal inhibitory concentration: > 30000 nM
Compound 3 ended at the assay's limit; the forecaster's own chance of this, stated with the estimate: 65%; the middle value lies on the limit itself.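

The steps among compound 1, compound 2 and compound 3 in this assay cannot be read, as all three values are limits, not numbers: the limit of > 30000 nM in this assay, at which 3 of the 3 values shown sit.

The compounds shown leave open whether any group at this place changes inhibition, and by how much.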